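Thiophene for fluorophenyl at the ring carbon of a pyrazoline

This account rests on a few compounds, and the source may have more. Where it says the series, first, only, none or still open, it means among the compounds named here.

Measured compounds:
- compound 1, `S=C(Nc1ccccc1)N1N=C(c2ccccc2)CC1c1ccc2c(c1)OCCO2`: 1850 nM
- compound 2, `Fc1ccc(C2=NN(C(=S)Nc3ccccc3)C(c3ccc4c(c3)OCCO4)C2)cc1`: 15700 nM

Both compounds were tested in a functional assay on A-375 cells (Homo sapiens) for antiproliferative activity, read by MTT assay, with a stated time of 48 h; on this read-out lower numbers stand for stronger inhibition of growth and higher numbers for weaker inhibition of growth. Compound 2 gives 15700 nM, the highest of the two numbers; its nearest neighbour is compound 1, which gives 1850 nM. Among the compounds with values here, the one step between measured compounds, an 8.5-fold higher number from compound 1 to compound 2 (0.93 log units; beyond the scatter), shows that adding a fluorine to the phenyl ring on the carbon with a double bond to nitrogen weakened growth inhibition by a clear margin.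

Compound 3, `S=C(Nc1ccccc1)N1N=C(c2cccs2)CC1c1ccc2c(c1)OCCO2`, has not been measured. It differs from compound 2 in one place: thiophen-2-yl in place of 4-fluorophenyl on a carbon with a double bond to nitrogen. Within the data shown here, no measured step covers a swap of the whole ring at this position, so the only guidance is indirect: the fluorinated ring of compound 2 sits well above the unsubstituted phenyl of compound 1, and thiophen-2-yl likewise carries no fluorine. The number for compound 3 is therefore expected to move back toward that of compound 1, with wide uncertainty, an expected step of a 4.5-fold lower number from compound 2 to compound 3 (0.65 log units; beyond the scatter). Compound 3 is estimated at 3500 nM, within a range from 900 nM to 14000 nM.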

Compound 3, concentration for 50% growth inhibition: 121000 nM
The estimate for compound 3 lay 35-fold (1.54 log units) below the measured number; measured number above the stated range.
By their numbers in this assay, from the lowest: compound 1; then compound 2; then compound 3.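

In this assay the choice of ring on the carbon with a double bond to nitrogen matters more than the earlier pair could show: thiophen-2-yl in place of 4-fluorophenyl gives a 7.7-fold higher number from compound 2 to compound 3 (0.89 log units; beyond the scatter) and thiophen-2-yl in place of phenyl gives a 65-fold higher number from compound 1 to compound 3 (1.82 log units; beyond the scatter) on the same read-out. The absence of fluorine therefore does not by itself bring a compound back toward compound 1, since compound 3 carries no fluorine yet has the highest number of the three, and at this position both six-membered aromatic rings of carbon only give lower numbers than the five-membered ring containing sulfur. Nothing measured here explains why this ring swap weakens growth inhibition so sharply.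

The compounds shown leave open whether the loss belongs to thiophen-2-yl specifically or to five-membered aromatic rings more broadly, a question that a furan-2-yl group at the same carbon could help to answer. They also leave open how a methoxy group or a chlorine in place of the fluorine of compound 2 would compare with the plain phenyl of compound 1.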